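Swapping an amide for a sulfonamide on a flexible chain

A few compounds are considered here, and "the series" means these few. Any claim that something is new, unique, unknown or untested is made for them only; others in the source may bear on it.

Compound 1 `O=C(NCCCNc1nccc(-c2c(-c3cccc(F)c3)nc3sccn23)n1)c1ccc(F)cc1` was tested in a functional assay on SK-MEL-28 cells (Homo sapiens) for cytotoxicity, read by MTT assay; on this read-out higher numbers stand for weaker inhibition and lower numbers for stronger inhibition. In this assay compound 1 reaches only the limit of the assay, > 20000 nM, so no number is known for it (the limit of > 20000 nM in this assay, at which 1 of the 3 values shown sits). Compound 2 `O=S(=O)(NCCCNc1nccc(-c2c(-c3cccc(F)c3)nc3sccn23)n1)c1ccccc1` gives 6850 nM in this assay, and compound 3 `O=S(=O)(NCCNc1nccc(-c2c(-c3cccc(F)c3)nc3sccn23)n1)c1ccc(Cl)cc1` gives 18600 nM there. Compound 4 `Cc1ccc(S(=O)(=O)NCCNc2nccc(-c3c(-c4cccc(F)c4)nc4sccn34)n2)cc1` is not yet measured; compared with compound 1, (((4-methylphenyl)sulfonyl)amino in place of (((4-fluorophenyl)carbonyl)amino)methyl on a saturated chain carbon, two bonds along the chain from a nitrogen on an aromatic ring). Among the measured compounds shown here, two measured steps bear on this change. Replacing the amide by a sulfonamide gave an at least 2.9-fold lower number from compound 1 to compound 2 (0.46 log units; beyond the scatter), whereas the closely matching replacement that leads to compound 3 gave an at least 1.0-fold lower number from compound 1 to compound 3 (0.03 log units; that floor lies within the scatter). Compound 4 is therefore expected to land near compound 3, with an estimated at least 1.3-fold lower number from compound 1 to compound 4 (0.12 log units; that floor lies within the scatter). The estimate for compound 4 is 15000 nM, ranging from 6000 nM to 40000 nM.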

Compound 4, half-maximal inhibitory concentration: > 20000 nM
Compound 4 gave a limit, no number; the forecaster's own chance of this, stated with the estimate: 30%; middle value at least 1.3-fold (0.12 log units) away from the limit.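

Compound 4 gives a limit, not a number, so the step from compound 1 cannot be read: the limit of > 20000 nM in this assay, at which 2 of the 4 values shown sit. Methyl in place of chloro on an aromatic carbon gives an at least 1.0-fold higher number from compound 3 to compound 4 (0.03 log units; that floor lies within the scatter), so no difference shows between these two. A sulfonamide alone is therefore not enough to lower the number, and only compound 2 stands apart, with an at least 2.9-fold higher number from compound 2 to compound 4 (0.46 log units; beyond the scatter).

That last step changes both the chain and the aromatic ring, so the compounds shown cannot say which change matters. As far as these compounds go, how an amine or a longer chain would behave in this place also stays open.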